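This account rests on a few compounds, and the source may have more. Where it says the series, first, only, none or still open, it means among the compounds named here.

Compound 1 `O=S(=O)(/C=C/c1ccc(F)cc1)Cc1ccc(Nc2ncnc3ccccc23)cc1` and compound 2 `O=S(=O)(/C=C/c1ccc(O)cc1)Cc1ccc(Nc2ncnc3ccccc23)cc1` share one core and differ only at one aromatic position, where compound 1 bears fluoro and compound 2 bears hydroxy. In a functional assay on NCI-H520 cells (Homo sapiens) (on this read-out higher numbers stand for weaker inhibition of growth and lower numbers for stronger inhibition of growth), compound 1 gives 13000 nM, and compound 2 gives 100000 nM, so the change of a 7.7-fold higher number from compound 1 to compound 2 (0.89 log units; beyond the scatter) is a modest step to a weaker result. Within the data shown here, compound 2 therefore stands with the higher of the two numbers measured so far, with compound 1 as its only neighbour.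

Compound 3 `O=S(=O)(/C=C/c1ccc(O)cc1)Cc1ccc(Nc2ncnc3ccc(Br)cc23)cc1` keeps the hydroxy of compound 2 and changes the core instead: bromo in place of hydrogen on an aromatic carbon. Among the measured compounds shown here, the one measured step, the exchange of fluoro for hydroxy, concerns a different position and a different kind of group, so no measured step bears directly on this change. With nothing to indicate a direction, the expectation for this assay is a step from compound 2 to compound 3 of a 1.4-fold lower number from compound 2 to compound 3 (0.15 log units; within the scatter), essentially within the scatter. Compound 3 is accordingly estimated at 70000 nM, with a range from 15000 nM to 200000 nM.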

Compound 3, concentration for 50% growth inhibition: 27000 nM
Estimate against measurement, compound 3: 2.6-fold (0.41 log units) above; measured number inside the range.
By their numbers in this assay, from the lowest: compound 1; then compound 3; then compound 2.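

Bromo in place of hydrogen on an aromatic carbon of the core, meta to a fused ring and para to a fused ring, gives a 3.7-fold lower number from compound 2 to compound 3 (0.57 log units; beyond the scatter) in this assay and so moves the result towards stronger inhibition of growth. The earlier compounds shown here showed a change only at the aromatic position that carries the fluoro or the hydroxy, whereas this step, modest but beyond the scatter, shows that the read-out also responds to a change on the core while the hydroxy stays in place. There is no evidence at hand that could account for this step.

The compounds shown leave open whether the gain belongs to bromo in particular or would also appear with another group on the same carbon, such as chloro, methoxy, an amine or a carboxylic acid. They also leave open whether bromo at this place would shift the number by a similar step when the hydroxy is replaced by the fluoro of compound 1, since a single step on a single background cannot show whether the two changes act independently.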